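A few compounds are considered here, and "the series" means these few. Any claim that something is new, unique, unknown or untested is made for them only; others in the source may bear on it.

In a functional assay on HeLa cells (Homo sapiens) for cytotoxicity, read by MTT assay, with a stated time of 24 h (a higher number here means a weaker inhibitor, a lower number a stronger inhibitor), three compounds sharing one core have been measured: compound 1 `CN1C/C(=C\c2ccc(F)cc2)C(=O)/C(=C/c2ccc(C#N)cc2)C1` gives 10200 nM, compound 2 `CN1C/C(=C\c2ccc(Cl)cc2)C(=O)/C(=C/c2ccc(C#N)cc2)C1` gives 11200 nM and compound 3 `CN1C/C(=C\c2ccc(Br)cc2)C(=O)/C(=C/c2ccc(C#N)cc2)C1` gives 5900 nM. Compound 3 stands within the scatter of both others, so the three cannot be ranked. Compound 4 `CN1C/C(=C\c2ccc(C#N)cc2)C(=O)/C(=C/c2ccc(C(F)(F)F)cc2)C1` carries trifluoromethyl in place of bromo on an aromatic carbon. Among the measured compounds shown here, no compound with this group has yet been measured. For the measured compounds named here, the steps that bear on it are the exchanges among fluoro, chloro and bromo: a 1.1-fold higher number from compound 1 to compound 2 (0.04 log units; within the scatter), a 1.7-fold lower number from compound 1 to compound 3 (0.24 log units; within the scatter) and a 1.9-fold lower number from compound 2 to compound 3 (0.28 log units; within the scatter). None leaves the scatter, so no clear shift is expected in this assay. The expected change is a 1.4-fold higher number from compound 3 to compound 4 (0.13 log units; within the scatter). Compound 4 is estimated at 8000 nM, with an expected range from 4000 nM to 16000 nM.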

Compound 4, half-maximal inhibitory concentration: 3210 nM
Estimate against measurement, compound 4: 2.5-fold (0.40 log units) above, and the stated range ends above it.
By their numbers in this assay, from the lowest: compounds 4, 3, 1 and 2 (each within the scatter of the next, the first and the last beyond it).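

In this assay, among the compounds shown here, trifluoromethyl gives the first exchange at this position to leave the scatter, though only modestly, both against chloro (a 3.5-fold lower number from compound 2 to compound 4 (0.54 log units; beyond the scatter)) and against fluoro (a 3.2-fold lower number from compound 1 to compound 4 (0.50 log units; beyond the scatter)). Against bromo it does not leave the scatter (a 1.8-fold lower number from compound 3 to compound 4 (0.26 log units; within the scatter)), so compound 3 and compound 4 cannot be ranked against each other. Nothing on hand explains these steps. The compounds shown leave open what an amine or a carboxylic acid on this aromatic carbon would give, and whether these steps hold with a group other than nitrile on the second aromatic ring.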